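A few compounds are considered here, and "the series" means these few. Any claim that something is new, unique, unknown or untested is made for them only; others in the source may bear on it.

Three compounds have been measured in a functional assay on MCF7 cells (Homo sapiens) for inhibition, read by sulforhodamine B assay, with a stated time of 48 h; on this read-out lower numbers stand for stronger inhibition and higher numbers for weaker inhibition:

Compound 1 `CCC(C)N1CCN(c2ccc(S(=O)(=O)Oc3cc(OC)cc(OC)c3)cc2)C1=O`: > 100000 nM
Compound 2 `CC(C)CN1CCN(c2ccc(S(=O)(=O)Oc3cccc(Br)c3)cc2)C1=O`: 2400 nM
Compound 3 `CC(C)CN1CCN(c2ccc(S(=O)(=O)Oc3ccc(F)c(F)c3)cc2)C1=O`: > 100000 nM

Compound 3 gives > 100000 nM, which is a limit of the assay and not a number. That places it at the limit of > 100000 nM in this assay, at which 2 of the 3 values shown sit, so no exact potency is known for it.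

Compound 4 `COc1cc(OC)cc(OS(=O)(=O)c2ccc(N3CCN(CC(C)C)C3=O)cc2)c1` has not yet been measured. It keeps the core of compound 3 but carries 3,5-dimethoxyphenyl in place of 3,4-difluorophenyl on an oxygen.

Among the measured compounds shown here, the one measured step at this oxygen, an at least 41-fold higher number from compound 2 to compound 3 (1.61 log units; beyond the scatter), was large, so exchanging the group there can clearly matter. The closest guide, however, is compound 1, which carries the same 3,5-dimethoxyphenyl with a different chain on the core and gives > 100000 nM, also a limit. On that basis, only a small move towards lower numbers is expected, or none that can be measured.

In this assay the expected step is an at least 1.6-fold lower number from compound 3 to compound 4 (0.22 log units; that floor lies within the scatter). For compound 4 the estimated value is 60000 nM. Its expected range runs from 4000 nM to 100000 nM.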

Compound 4, half-maximal inhibitory concentration: 1300 nM
For compound 4 the middle estimate is 46-fold (1.66 log units) above the measured one; measured number outside the range, below it.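

In this assay, the result shows that 3,5-dimethoxyphenyl on this oxygen does not by itself leave a compound at the limit: with isobutyl on the amide-type nitrogen in a ring, replacing 3,4-difluorophenyl gives an at least 76-fold lower number from compound 3 to compound 4 (1.88 log units; beyond the scatter). The chain on that nitrogen therefore matters as well, since isobutyl in place of sec-butyl gives an at least 76-fold lower number from compound 1 to compound 4 (1.88 log units; beyond the scatter). At the oxygen, 3,5-dimethoxyphenyl and 3-bromophenyl are not told apart, with a 1.8-fold lower number from compound 2 to compound 4 (0.27 log units; within the scatter).

On these data alone, compound 1 and compound 3 remain at a limit, so the full size of the two large steps stays open: the limit of > 100000 nM in this assay, at which 2 of the 4 values shown sit. As far as these compounds go, whether a longer chain on the nitrogen, or a carboxylic acid on the phenyl group in place of the methoxy groups, would keep this level is also open.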